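Quinone in Place of Hydroquinone on a Pyrazole Scaffold

A few compounds are considered here, and "the series" means these few. Any claim that something is new, unique, unknown or untested is made for them only; others in the source may bear on it.

Compound 1 `COc1ccc(OC)c(-c2cc(-c3ccccc3)nn2-c2ccc(S(=O)(=O)NC(C)=O)cc2)c1`: 50700 nM
Compound 2 `NS(=O)(=O)c1ccc(-n2nc(-c3ccccc3)cc2-c2cc(O)ccc2O)cc1`: 98200 nM
Compound 3 `CC(=O)NS(=O)(=O)c1ccc(-n2nc(-c3ccccc3)cc2-c2cc(O)ccc2O)cc1`: 100000 nM

These three compounds were tested in a functional assay on cells (Cancer cell lines, Homo sapiens) for cytotoxicity, read by sulforhodamine B assay, with a stated time of 48 h; a lower number here means a stronger inhibitor of growth, a higher number a weaker inhibitor of growth. Compound 3 gives the highest of the three numbers, yet its distance to compound 2 and to compound 1 lies within the scatter, so the three compounds cannot be told apart on these data.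

Compound 4 `CC(=O)NS(=O)(=O)c1ccc(-n2nc(-c3ccccc3)cc2C2=CC(=O)C=CC2=O)cc1` has not been measured. It differs from compound 3 in one place: a group of 8 heavy atoms (6 carbon, 2 oxygen; one six-membered non-aromatic ring of carbon only) in place of a group of 8 heavy atoms (6 carbon, 2 oxygen; one six-membered aromatic ring of carbon only), on an aromatic carbon. The two measured steps touch related parts of the molecule without covering this change. The step of a 2.0-fold higher number from compound 1 to compound 3 (0.29 log units; within the scatter) replaced the two methyl ethers on the same ring with hydroxyl groups and stayed within the scatter. The step of a 1.0-fold higher number from compound 2 to compound 3 (0.01 log units; within the scatter) concerned the sulfonamide nitrogen and also stayed within the scatter. Within the data shown here, no measured pair shows an aromatic ring giving way to a non-aromatic ring with four double bonds outside aromatic rings, so nothing here speaks for a step beyond the scatter in either direction, and the uncertainty is correspondingly wide.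

On that basis compound 4 is expected to give about 65000 nM, with a likely range from 15000 nM to 100000 nM. The estimated step is a 1.5-fold lower number from compound 3 to compound 4 (0.19 log units; within the scatter).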

Compound 4, concentration for total growth inhibition: 100000 nM
For compound 4 the middle estimate is 1.5-fold (0.19 log units) below the measured one; low and high end bracket the measured number.
By their numbers in this assay, from the lowest: compounds 1, 2, 3 and 4 (each within the scatter of the next).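

In this assay, replacing the 2,5-dihydroxyphenyl group on this aromatic carbon with the group holding one six-membered non-aromatic ring of carbon only gave no change at the digits printed from compound 3 to compound 4 (within the scatter), even though the entering group has no hydrogen-bond donors and the leaving group has them. Compared with the 2,5-dimethoxyphenyl group of compound 1, the same entering group gave a 2.0-fold higher number from compound 1 to compound 4 (0.29 log units; within the scatter), so the three groups seen at this position in compounds 1, 3 and 4 cannot be told apart in this assay. No independent evidence bears on this result.

From the compounds shown here alone, it remains open whether an amine or a carboxylic acid on this aromatic carbon would give a number that differs beyond the scatter from those of compound 3 and compound 4. Also open, going by these compounds, is how the non-aromatic ring would read with the plain sulfonamide of compound 2, or with a longer chain in place of the acetyl group on the sulfonamide nitrogen.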